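A few compounds are considered here, and "the series" means these few. Any claim that something is new, unique, unknown or untested is made for them only; others in the source may bear on it.

Compound 1 `CCCC(Oc1ccc(-n2cc(OC)cn2)cc1)c1ccc(C(=O)NCCC(=O)O)cc1`: in a functional assay on cells for antagonist activity at Glucagon receptor (Homo sapiens), read by cAMP accumulation, in the presence of a further agent that is not named here (on this read-out higher numbers stand for weaker inhibition and lower numbers for stronger inhibition), compound 1 gives > 23000 nM, a limit of the assay rather than a number.
Compound 2 `CCCC(Oc1ccc(-n2cc(C(F)(F)F)c(C)n2)cc1)c1ccc(C(=O)NCCC(=O)O)cc1`: in this assay compound 2 gives 8300 nM.
Compound 3 `CCCC(Oc1ccc(-n2cc(Cl)cn2)cc1)c1ccc(C(=O)NCCC(=O)O)cc1`: in this assay compound 3 gives 6500 nM.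

Compound 1 thus stands only at the limit of > 23000 nM in this assay, at which 1 of the 3 values shown sits, with no exact number. Compound 4 `CCCC(Oc1ccc(-n2cc(C(F)(F)F)cn2)cc1)c1ccc(C(=O)NCCC(=O)O)cc1` differs from it by trifluoromethyl in place of methoxy on an aromatic carbon. Within the data shown here, two measured steps bear on this: an at least 2.7-fold lower number from compound 1 to compound 2 (0.44 log units; beyond the scatter) and an at least 3.5-fold lower number from compound 1 to compound 3 (0.54 log units; beyond the scatter), both of which also remove the methoxy, and between their products a 1.3-fold lower number from compound 2 to compound 3 (0.11 log units; within the scatter). A step of similar size is therefore expected from compound 1 to compound 4 in this assay, namely an at least 3.2-fold lower number from compound 1 to compound 4 (0.51 log units; beyond the scatter). Compound 4 is estimated at 7000 nM, within 2500 nM to 20000 nM.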

Compound 4, antagonist equilibrium constant: 5100 nM
Estimate against measurement, compound 4: 1.4-fold (0.14 log units) above, and the stated range covers the measured number.
By their numbers in this assay, from the lowest: compounds 4, 3 and 2 (each within the scatter of the next). At a limit, above all of these: compound 1.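

In this assay, trifluoromethyl on this aromatic carbon also gives a stronger result than methoxy, with an at least 4.5-fold lower number from compound 1 to compound 4 (0.65 log units; beyond the scatter) and so all three replacements of methoxy shown point the same way. Chloro in its place gives a 1.3-fold lower number from compound 3 to compound 4 (0.11 log units; within the scatter) and the added methyl gives a 1.6-fold lower number from compound 2 to compound 4 (0.21 log units; within the scatter) and so these three compounds cannot be told apart here. On these data alone, compound 1 stands only at a limit, so the full size of its steps is unknown: the limit of > 23000 nM in this assay, at which 1 of the 4 values shown sits.

As far as these compounds go, whether an amine or a nitrile on this carbon would behave like chloro and trifluoromethyl or like methoxy stays open.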